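This account rests on a few compounds, and the source may have more. Where it says the series, first, only, none or still open, it means among the compounds named here.

Compound 1, `COC(=O)c1ccc(NCc2cncn2Cc2ccc(F)cc2F)cc1-c1ccccc1`, gives > 1000 nM in a toxicity assay on NIH3T3 cells (Mus musculus) for cytotoxicity, read by resazurin assay (on this read-out higher numbers stand for an effect only at larger amounts of compound and lower numbers for an effect already at smaller amounts), which is a limit of the measurement rather than a number.
Compound 2, `Cc1ccccc1-c1ccc(Cn2cncc2CNc2ccc(-c3nc4ccccc4s3)c(-c3ccccc3)c2)cc1`, gives > 1000 nM, again a limit.
Compound 3, `Fc1ccc(Cn2cncc2CNc2ccc(-c3nc4ccccc4s3)c(-c3ccccc3)c2)c(F)c1`, gives > 1000 nM, also a limit.

Compound 1 therefore stands at the edge of what this assay can report, and so do the two compounds measured alongside it: the limit of > 1000 nM in this assay, at which 3 of the 3 values shown sit. For the measured compounds named here, the single step between compounds that differ in one place, a step that the two limits leave unreadable from compound 1 to compound 3, cannot be read, since both ends of it are limits.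

Compound 4, `COC(=O)c1ccc(NCc2cncn2Cc2ccccc2[N+](=O)[O-])cc1-c1ccccc1`, differs from compound 1 by 2-nitrophenyl in place of 2,4-difluorophenyl on a saturated chain carbon bound to an aromatic nitrogen. Going by the values given here, no measured step touches this part of the molecule, and the one step that is available is unreadable, so the only guidance is that every value seen so far sits at the limit.

Compound 4 is therefore expected to give 3000 nM, within 1000 nM to 10000 nM, most likely again reported only as a limit. The expected step that the limit leaves unreadable from compound 1 to compound 4 is thus one of no change beyond the scatter, as far as a step from a limit can be stated.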

Compound 4, half-maximal effective concentration: 10000 nM
Compound 4: the middle estimate sits 3.3-fold (0.52 log units) below what was measured, and the stated range covers the measured number.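

The step between compound 1 and compound 4 cannot be read: the value of compound 1 is only a limit, so it gives no number to compare. The compounds shown leave open whether 2-nitrophenyl in place of 2,4-difluorophenyl changes the result in this assay at all.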